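The source may hold more compounds than are shown below. What is called first, only, known or untested is meant among the compounds shown, and "the series" means these compounds.

Compound 3 `CCS(=O)(=O)Nc1cc(-c2ccc3ncnc(Nc4ccc(OC)c(OC)c4)c3c2)cnc1OC` gives 2590 nM in a functional assay on BT-549 cells (Homo sapiens) for cytotoxicity, read by sulforhodamine B assay, with a stated time of 72 h (a higher number here means a weaker inhibitor, a lower number a stronger inhibitor), the second highest of the three numbers recorded. Its nearest neighbour is compound 1 `CCS(=O)(=O)Nc1cc(-c2ccc3ncnc(Nc4ccc(F)cc4F)c3c2)cnc1OC`, which gives 2480 nM, a gap within the scatter; the furthest is compound 2 `CCS(=O)(=O)Nc1cc(-c2ccc3ncnc(Nc4ccc(OC(F)(F)F)cc4)c3c2)cnc1OC`, which gives 8240 nM. Compound 4 `CCS(=O)(=O)Nc1cc(-c2ccc3ncnc(Nc4cccc(C(=O)OC)c4)c3c2)cnc1OC` is obtained by the change (3-(methoxycarbonyl)phenyl in place of 3,4-dimethoxyphenyl on a nitrogen on an aromatic ring). Going by the values given here, the steps that bear on it all vary the same aryl group: a 1.0-fold higher number from compound 1 to compound 3 (0.02 log units; within the scatter), a 3.3-fold higher number from compound 1 to compound 2 (0.52 log units; beyond the scatter) and a 3.2-fold lower number from compound 2 to compound 3 (0.50 log units; beyond the scatter). Two of these three are modest and one is within the scatter, so a modest step in this assay in either direction, or none beyond the scatter, is expected for compound 4, shown by a 1.4-fold higher number from compound 3 to compound 4 (0.13 log units; within the scatter). Compound 4 is therefore estimated at 3500 nM, with a range from 1200 nM to 10000 nM.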

Compound 4, half-maximal inhibitory concentration: 1080 nM
The estimate for compound 4 lay 3.2-fold (0.51 log units) above the measured number; the measured number lies below the stated range.
By their numbers in this assay, from the lowest: compound 4; then compounds 1 and 3 (each within the scatter of the next); then compound 2.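

In this assay the 3-(methoxycarbonyl)phenyl group on the nitrogen gives a 2.4-fold lower number from compound 3 to compound 4 (0.38 log units; beyond the scatter) and a 2.3-fold lower number from compound 1 to compound 4 (0.36 log units; beyond the scatter) and a 7.6-fold lower number from compound 2 to compound 4 (0.88 log units; beyond the scatter), which makes compound 4 the strongest inhibitor of the four shown and the first change here to beat both compound 1 and compound 3. The leaving and entering groups have equal heavy-atom, donor and acceptor counts, so those counts do not separate compound 3 from compound 4. No measurement available here accounts for the gain. Going by these compounds, what a carboxylic acid or an amide in place of the methoxycarbonyl group would give remains open.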